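Fluorophenyl isomer swap on the shared core of compound 3

A few compounds are considered here, and "the series" means these few. Any claim that something is new, unique, unknown or untested is made for them only; others in the source may bear on it.

Compound 3 `Oc1cccc(-c2cc(-c3ccccc3F)cc(-c3cccc(O)c3)n2)c1` stands as the lowest of the two numbers shown in a functional assay on T47D cells (Homo sapiens) for inhibition (a lower number here means a stronger inhibitor, a higher number a weaker inhibitor), at 4370 nM; compound 1 `Oc1cccc(-c2cc(-c3ccccc3F)cc(-c3ccccc3O)n2)c1` gives 24200 nM. Compound 2 `Oc1cccc(-c2cc(-c3cccc(F)c3)cc(-c3ccccc3O)n2)c1` reaches only a limit of the assay, > 50000 nM. Compound 4 `Oc1cccc(-c2cc(-c3cccc(F)c3)cc(-c3cccc(O)c3)n2)c1` is compound 3 with the change (3-fluorophenyl in place of 2-fluorophenyl on an aromatic carbon). The same replacement has been measured once, giving an at least 2.0-fold higher number from compound 1 to compound 2 (0.31 log units; beyond the scatter), a step that ends at the limit of > 50000 nM in this assay, at which 1 of the 3 values shown sits. Compound 3 itself is reached from compound 1 by a 5.5-fold lower number from compound 1 to compound 3 (0.74 log units; beyond the scatter). Within the data shown here, the one relevant step points toward a weaker inhibitor, so a modest step in that direction is expected for compound 4, a 2.7-fold higher number from compound 3 to compound 4 (0.44 log units; beyond the scatter). The estimated value for compound 4 in this assay is 12000 nM, with a range from 5000 nM to 40000 nM.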

Compound 4, half-maximal inhibitory concentration: 21300 nM
Compound 4: the middle estimate sits 1.8-fold (0.25 log units) below what was measured; the range from low to high includes it.
By their numbers in this assay, from the lowest: compound 3; then compounds 4 and 1 (each within the scatter of the next). At a limit, above all of these: compound 2.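

In this assay the change to 3-fluorophenyl from 2-fluorophenyl, opposite the ring nitrogen, now has a step free of any limit (a 4.9-fold higher number from compound 3 to compound 4 (0.69 log units; beyond the scatter)) and points the same way on both cores: the same change on two cores in this assay, an at least 2.0-fold higher number (0.31 log units; beyond the scatter) from compound 1 to compound 2 and a 4.9-fold higher number (0.69 log units; beyond the scatter) from compound 3 to compound 4; the limit leaves it open whether they differ.
From the compounds shown here alone, the change to 3-hydroxyphenyl from 2-hydroxyphenyl also points the same way with either fluorophenyl group (an at least 2.3-fold lower number from compound 2 to compound 4 (0.37 log units; beyond the scatter)), but this step starts from the limit of compound 2, so its full size stays open: the same change on two cores in this assay, a 5.5-fold lower number (0.74 log units; beyond the scatter) from compound 1 to compound 3 and an at least 2.3-fold lower number (0.37 log units; beyond the scatter) from compound 2 to compound 4; the limit leaves it open whether they differ.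

Open remains how an amine or a carboxylic acid in place of the fluorine on this ring would read.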